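The source may hold more compounds than are shown below. What is called first, only, known or untested is meant among the compounds shown, and "the series" means these compounds.

Measured compounds:
- compound 1, `Nc1ncnc2c1c(-c1cc(C3CC3)on1)nn2C1CCOCC1`, 5 nM
- compound 2, `CC(C)n1nc(/C=N/O)c2c(N)ncnc21`, 4900 nM

In an assay on isolated protein for inhibition of proto-oncogene tyrosine-protein kinase receptor Ret (Homo sapiens), read by radiometric assay and 33P incorporation, in the presence of a further agent that is not named here (a higher number here means a weaker inhibitor, a lower number a stronger inhibitor), compound 1 gives 5 nM, the lowest of the two numbers shown. In this assay, among the measured compounds shown here, compound 2 gives 4900 nM, a far higher number, beyond the scatter; the two structures differ in more than one place, so the two values show only that compound 1 is much the stronger inhibitor of the pair.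

Compound 3, `Cn1nc(-c2cc(C3CC3)on2)c2c(N)ncnc21`, has not yet been measured in this assay. It differs from compound 1 in one place: methyl in place of oxan-4-yl on an aromatic nitrogen. For the measured compounds named here, no step between measured compounds isolates this change, so the expectation rests on the wide gap between compound 1 and compound 2 and on the size of the group that leaves. The step from compound 1 to compound 3 is expected to weaken inhibition by a moderate amount, a 6.0-fold higher number from compound 1 to compound 3 (0.78 log units; beyond the scatter), beyond the scatter but nowhere near the gap to compound 2. Compound 3 is therefore estimated at 30 nM in this assay, within a range of 8 nM to 150 nM.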

Compound 3, half-maximal inhibitory concentration: 27 nM
The estimate for compound 3 lay 1.1-fold (0.05 log units) above the measured number, and the stated range covers the measured number.
By their numbers in this assay, from the lowest: compound 1; then compound 3; then compound 2.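

In this assay, among the compounds shown here, the substituent on the aromatic nitrogen can now be read on its own for the first time: with the shared core and the 5-cyclopropyl-1,2-oxazol-3-yl group unchanged, methyl in place of oxan-4-yl gives a 5.4-fold higher number from compound 1 to compound 3 (0.73 log units; beyond the scatter), a modest step but one beyond the scatter. The six-membered non-aromatic ring is therefore not needed for inhibition in the nanomolar range, since compound 3, with only methyl at this position, still gives 27 nM. The size of the step does show that the change from oxan-4-yl to methyl is not neutral, but no measurement shown here accounts for it.

The compounds shown leave open whether the step follows the loss of the ring as a whole or the loss of its oxygen, a question that a cyclohexyl group on this aromatic nitrogen would address. They also leave open how the number moves with groups of intermediate size, such as ethyl or cyclopentyl, at the same place on the core of compound 3.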